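The source may hold more compounds than are shown below. What is called first, only, known or untested is meant among the compounds shown, and "the series" means these compounds.

In a functional assay on PC-3 cells (Homo sapiens) for cytotoxicity, read by resazurin assay, with a stated time of 48 h (on this read-out lower numbers stand for stronger inhibition and higher numbers for weaker inhibition), compound 2 `C=C(C)[C@@H]1CC=C(CN(OC)C2OC[C@@H](O)[C@H](O)[C@H]2O)CC1` gives 152000 nM and lies within the usual scatter of compound 3 `C=C(C)[C@@H]1CC=C(CN(OC)C2O[C@H](CO)[C@@H](O)[C@H](O)[C@H]2N=[N+]=[N-])CC1` at 176000 nM on this measure, so those two readings cannot be told apart. Compound 1 `C=C(C)[C@@H]1CC=C(CN(OC)C2O[C@H](CN=[N+]=[N-])[C@@H](N=[N+]=[N-])[C@H](O)[C@H]2O)CC1` gives 57000 nM as its reading, a lower number than compound 2 shows, and that gap lies beyond the scatter. Compound 4 `C=C(C)[C@@H]1CC=C(CN(OC)C2O[C@H](CN=[N+]=[N-])[C@@H](O)[C@H](O)[C@H]2O)CC1` differs from compound 2 by a single change, azidomethyl in place of hydrogen on a saturated ring carbon, next to the ring oxygen (azidomethyl in place of hydrogen on a saturated ring carbon). Within the data shown here, no measured pair isolates this change. Compound 1 also carries azidomethyl, and its reading of 57000 nM points toward lower numbers, yet it differs from compound 2 in more than this one place, so it is only a loose guide. A small move toward a lower number is therefore expected, perhaps none beyond the scatter, and the estimated step (a 1.5-fold lower number from compound 2 to compound 4 (0.18 log units; within the scatter)) reflects that caution. The estimate for compound 4 is 100000 nM in this assay, with an expected range from 45000 nM to 200000 nM around it.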

Compound 4, half-maximal inhibitory concentration: 182000 nM
Beside the measured number, compound 4's estimate is 1.8-fold (0.26 log units) below it; low and high end bracket the measured number.
By their numbers in this assay, from the lowest: compound 1; then compounds 2, 3 and 4 (each within the scatter of the next).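

In this assay, azidomethyl in place of hydrogen on the saturated ring carbon next to the ring oxygen gives a 1.2-fold higher number from compound 2 to compound 4 (0.08 log units; within the scatter) and so does not by itself separate these two compounds. The larger difference appears at another place: hydroxy in place of azido on a saturated ring carbon gives a 3.2-fold higher number from compound 1 to compound 4 (0.50 log units; beyond the scatter) and thus ties the lower number of compound 1 to the azido group that compound 4 lacks, with azidomethyl present in both. No measurement at hand explains either step.

As far as these compounds go, it remains open whether an amine or a longer chain in place of azidomethyl would change the reading at this position. It is also unclear whether the azido group that sets compound 1 apart from compound 4 would give a lower number without azidomethyl also present.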